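The source may report more compounds than this note shows. Statements on the series, on what has been measured and on what is new or still open speak of the compounds shown alone.

Compound 1 `O=C(OCc1ccccc1)c1ccsc1NC(=O)[C@@H]1CCCN1` and compound 2 `O=C(Oc1ccccc1)c1ccsc1NC(=O)[C@@H]1CCCN1` share one core and differ only in the group on an oxygen next to a carbonyl group. In a functional assay on HeLa cells (Homo sapiens) for inhibition (a lower number here means a stronger inhibitor of growth, a higher number a weaker inhibitor of growth), compound 1 gives only a limit, > 250 ug/mL. In this assay compound 2 also gives only a limit, > 250 ug/mL. The step that the two limits leave unreadable from compound 1 to compound 2 cannot be sized because of the limit of > 250 ug/mL in this assay, at which 2 of the 2 values shown sit. Compound 3 `O=C(OCC(Cl)(Cl)Cl)c1ccsc1NC(=O)[C@@H]1CCCN1` carries 2,2,2-trichloroethyl in place of phenyl on an oxygen next to a carbonyl group. For the measured compounds named here, no measured step here reaches beyond the limit, so it gives no direction. Compound 3 is expected to stay near that limit, a step that the limit leaves unreadable from compound 2 to compound 3. Compound 3 is estimated at 300 ug/mL, between 80 ug/mL and 1000 ug/mL.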

Compound 3, concentration for 50% growth inhibition: > 250 ug/mL
Compound 3: only a limit was reported (the forecaster's own chance of this, stated with the estimate: 70%); the middle value is on the limit's open side.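

In this assay compound 3 gives only a limit, > 250 ug/mL. For the compounds shown here, no step among compound 1, compound 2 and compound 3 can be read: the limit of > 250 ug/mL in this assay, at which 3 of the 3 values shown sit. The compounds shown leave open whether the group on an oxygen next to a carbonyl group affects growth inhibition at all.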